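Chloro for hydrogen on the shared core of compound 1

This account rests on a few compounds, and the source may have more. Where it says the series, first, only, none or still open, it means among the compounds named here.

Three compounds of the series have numbers in a functional assay on Hs-578T cells (Homo sapiens) for cytotoxicity, read by sulforhodamine B assay, with a stated time of 48 h; on this read-out lower numbers stand for stronger inhibition of growth and higher numbers for weaker inhibition of growth. Compound 1 `ClCc1ccc(Cn2cnc3c(Cl)ncnc32)cc1` gives 38900 nM in this assay. Compound 2 `Nc1nc(Cl)c2ncn(Cc3ccccc3CCl)c2n1` gives 77600 nM, and its number and that of compound 1 lie within the scatter of each other. Compound 3 `ClCc1cccc(Cn2cnc3nc(Cl)nc(Cl)c32)c1` gives 2810 nM, a number well below that of compound 1 and beyond the scatter; compound 3 differs from compound 1 in more than one place, so no single step can be read from that pair. Compound 1 thus stands second highest of the three numbers, nearest compound 2 and furthest from compound 3.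

Compound 4 `ClCc1ccc(Cn2cnc3c(Cl)nc(Cl)nc32)cc1` is not yet measured. It differs from compound 1 by chloro in place of hydrogen on an aromatic carbon. Among the measured compounds shown here, no step between two measured compounds isolates this change. For the measured compounds named here, the only pointer is compound 3, which also carries a second chloro on its core and gives 2810 nM in this assay, but it differs from compound 1 elsewhere as well, so the pointer is indirect.

For compound 4 a fall in the number is expected, with a 5.6-fold lower number from compound 1 to compound 4 (0.74 log units; beyond the scatter) estimated as a step beyond the scatter. Compound 4 is estimated at 7000 nM in this assay, in the range 2000 nM to 25000 nM.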

Compound 4, concentration for total growth inhibition: 5750 nM
Compound 4: middle estimate off by 1.2-fold (0.09 log units), on the high side; low and high end bracket the measured number.
By their numbers in this assay, from the lowest: compound 3; then compound 4; then compounds 1 and 2 (each within the scatter of the next).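

In this assay the aromatic carbon between two ring nitrogen atoms now has a direct reading: chloro in place of hydrogen gives a 6.8-fold lower number from compound 1 to compound 4 (0.83 log units; beyond the scatter), with nothing else on the structure changed. Among the compounds shown here, the other compounds offered no pair differing in this place alone, so this is the only evidence that a substituent on this carbon moves the number beyond the scatter in these cells. No measurement at hand accounts for the size or direction of the step.

As far as these compounds go, whether the fall is specific to chloro or would also appear with another group on this carbon stays open; fluoro, bromo, methyl or methoxy there would separate those cases. The reading also rests on a single pair carrying the chloromethyl group on the same benzyl position, so whether chloro on this carbon gives a step of similar size with the chloromethyl group placed elsewhere on the benzyl ring remains unresolved.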